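The compounds below may be only part of what the source reports. "The series", "measured", "known", "first", "only" and "open" are said of these compounds alone.

Working notes on the series.

The series shares a core in which a pyridinylmethyl group sits on a nitrogen that is either an amine nitrogen or an amide-type nitrogen. Compound 1 `C[C@@H](NC(=O)[C@H](CCCNC(=N)N)NC(=O)c1ccc(CN(Cc2ccc(F)cc2)Cc2ccccn2)cc1)c1cccc2ccccc12` carries pyridin-2-yl on a saturated chain carbon bound to an amine nitrogen. In an assay on Jurkat cells for displacement of a labelled ligand from C-X-C chemokine receptor type 4 (Homo sapiens), tested at 10 uM (a higher number here means more inhibition at the concentration tested (going by the name of the read-out), a lower number less inhibition), compound 1 gives 0%. Compound 2 `C[C@@H](NC(=O)[C@H](CCCNC(=N)N)NC(=O)c1ccc(CN(Cc2ccc(F)cc2)Cc2cccnc2)cc1)c1cccc2ccccc12` differs from compound 1 by pyridin-3-yl in place of pyridin-2-yl on a saturated chain carbon bound to an amine nitrogen. In this assay compound 2 gives 6%, so that a number 6 percentage points higher from compound 1 to compound 2 (within the scatter).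

Compound 3 `C[C@H](NC(=O)[C@H](CCCNC(=N)N)NC(=O)c1ccc(CN(Cc2ccccn2)C(=O)c2ccc(F)cc2)cc1)c1cccc2ccccc12` has a different core; the difference between the core of compound 3 and the core of compound 1 is not broken down here. In this assay compound 3 gives 36%, which stands above both compound 2 and compound 1 by margins beyond the scatter.

Compound 4 `C[C@H](NC(=O)[C@H](CCCNC(=N)N)NC(=O)c1ccc(CN(Cc2cccnc2)C(=O)c2ccc(F)cc2)cc1)c1cccc2ccccc12` is not yet measured and differs from compound 3 by pyridin-3-yl in place of pyridin-2-yl on a saturated chain carbon bound to an amide-type nitrogen. This is the same kind of change as that from compound 1 to compound 2, though not the same: there the place is on a saturated chain carbon bound to an amine nitrogen, here on a saturated chain carbon bound to an amide-type nitrogen. Since the step from compound 1 to compound 2 stayed within the scatter, the step from compound 3 to compound 4 is expected to be small as well, estimated at a number 2 percentage points higher from compound 3 to compound 4 (within the scatter). Compound 4 in this assay is accordingly expected to give about 38%, with the estimate spanning 22% to 54%.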

Compound 4, a percentage reported as inhibition, at one concentration (the size of the read-out at that concentration, not a potency): 14%
Compound 4: middle estimate off by 24 percentage points, on the high side, and the stated range ends above it.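

In this assay, pyridin-3-yl in place of pyridin-2-yl on a saturated chain carbon bound to an amide-type nitrogen gives a number 22 percentage points lower from compound 3 to compound 4 (beyond the scatter), and the change does not carry over unchanged from the core of compound 1 to the core of compound 3: the same change on two cores in this assay, a number 6 percentage points higher (within the scatter) from compound 1 to compound 2 and a number 22 percentage points lower (beyond the scatter) from compound 3 to compound 4, 28 percentage points apart, beyond the scatter of two such steps. A step read on one of these two cores is therefore no safe guide to the same change on the other, although this rests on a single pair per core and on values at one concentration, which are not potencies. The data do not show which feature of the cores is responsible, as the difference between them is not broken down into single changes, nor how much room the read-out leaves on the first core, where compound 1 gives 0%.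

On these data alone, it remains open how pyridin-4-yl or phenyl on a saturated chain carbon bound to an amide-type nitrogen would compare with the pyridin-2-yl of compound 3, and how either group would behave on the core of compound 1. Also open, as far as these compounds go, is whether the gap between the two pyridine isomers on the core of compound 3 would hold up in a full concentration-response measurement.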